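Expected Macrophage Tolerance of Compound 4 from Three Neighbours

The compounds below may be only part of what the source reports. "The series", "measured", "known", "first", "only" and "open" are said of these compounds alone.

Of the compounds shown here, three that share one core have been tested in an ADME assay on cells (Macrophage, Homo sapiens) for cytotoxicity, read by MTT assay, with a stated time of 24 h; a higher number here means that more compound is tolerated, a lower number that less compound is tolerated. Compound 1 `COc1ccc(/C=C/c2ncc([N+](=O)[O-])n2CC(C)O)cc1` gives 560 nM. Compound 2 `CC(O)Cn1c([N+](=O)[O-])cnc1/C=C/c1ccc(Cl)cc1` gives 980 nM. Compound 3 `CC(O)Cn1c([N+](=O)[O-])cnc1/C=C/c1ccc(Cl)cc1Cl` gives 810 nM. On paper compound 2 carries the top number of the three, yet the two steps that link it to the others, a 1.8-fold higher number from compound 1 to compound 2 (0.24 log units; within the scatter) and a 1.2-fold lower number from compound 2 to compound 3 (0.08 log units; within the scatter), both stay within the scatter, so the three compounds cannot really be told apart in this assay.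

Compound 4 `CC(O)Cn1c([N+](=O)[O-])cnc1/C=C/c1ccccc1Br` differs from compound 2 by 2-bromophenyl in place of 4-chlorophenyl on a double-bonded chain carbon bound to a double-bonded chain carbon. Both measured steps also altered only the group on this aromatic ring, one swapping chloro for methoxy and one adding a second chloro, and neither moved the number beyond the scatter. Within the data shown here, no measured step shows a halogen moved to a different ring position, so that part of the change is untested. The step from compound 2 to compound 4 in this assay is therefore expected to be modest, a 1.1-fold lower number from compound 2 to compound 4 (0.04 log units; within the scatter). Compound 4 is expected to give about 900 nM, with a likely range from 400 nM to 2000 nM.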

Compound 4, half-maximal cytotoxic concentration: 490 nM
Estimate against measurement, compound 4: 1.8-fold (0.26 log units) above, and the stated range covers the measured number.
By their numbers in this assay, from the lowest: compounds 4, 1, 3 and 2 (each within the scatter of the next).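

In this assay the change to 2-bromophenyl gives a 2.0-fold lower number from compound 2 to compound 4 (0.30 log units; within the scatter) and so stays within the scatter, even though this is the first step shown in which the halogen differs in both kind and ring position. At this place on the chain, then, neither change nor the two together separates compound 4 from compound 2, but a single step cannot show what each contributes alone. No measurement shown here accounts for the size of this step.

The compounds shown leave open how a matched pair such as 2-chlorophenyl and 4-bromophenyl would divide the step between halogen and position. They also leave open whether a ring bearing an amine or a carboxylic acid would stay within the scatter of these halogen compounds.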